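The source may report more compounds than this note shows. Statements on the series, on what has been measured and on what is new or still open speak of the compounds shown alone.

The measured compounds and their numbers in a physicochemical assay for solubility, with a stated time of 18 h, at pH 7.4; a higher number here means a more soluble compound, a lower number a less soluble compound:
compound 1, `CC(C)Cc1ccc2c(NCCCNCc3ccco3)ccnc2c1`, gives 4200 nM
compound 2, `Fc1ccc(Oc2ccc3c(NCCCNCc4ccco4)ccnc3c2)cc1`, gives 14500 nM
compound 3, `c1ccc(Oc2ccc3c(NCCCNCc4ccco4)ccnc3c2)cc1`, gives 14500 nM

Compound 1 stands lowest of the three. The two steps leading away from it, a 3.5-fold higher number from compound 1 to compound 2 (0.54 log units; beyond the scatter) and a 3.5-fold higher number from compound 1 to compound 3 (0.54 log units; beyond the scatter), are both beyond the scatter, whereas no change at the digits printed from compound 2 to compound 3 (within the scatter).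

Compound 4, `COc1cccc(CNCCCNc2ccnc3cc(CC(C)C)ccc23)c1O`, has not yet been measured. It differs from compound 1 in one place: 2-hydroxy-3-methoxyphenyl in place of furan-2-yl on a saturated chain carbon bound to an amine nitrogen. All three measured steps concern a group on an aromatic carbon of the shared core, or a single fluorine on that group, and leave the furan-2-yl untouched. For the measured compounds named here, none of them therefore bears on the change made in compound 4, and no measured step exists at the saturated chain carbon bound to an amine nitrogen. Without a comparison to lean on, the expectation for compound 4 is a number close to that of compound 1, with an expected step of a 1.2-fold higher number from compound 1 to compound 4 (0.08 log units; within the scatter) that stays within the scatter, while a shift in either direction cannot be ruled out. The estimate for compound 4 in this assay is 5000 nM, with an expected range from 1500 nM to 16000 nM.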

Compound 4, solubility: 4200 nM
For compound 4 the middle estimate is 1.2-fold (0.08 log units) above the measured one; the range from low to high includes it.
By their numbers in this assay, from the lowest: compounds 1 and 4 (each within the scatter of the next); then compounds 2 and 3 (each within the scatter of the next).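

For the compounds shown here, the earlier compounds varied only a group on an aromatic carbon of the shared core, so this is the first reading at the saturated chain carbon bound to an amine nitrogen, and in this assay the change gives no change at the digits printed from compound 1 to compound 4 (within the scatter) for this pair. The swap itself is not a small one: furan-2-yl, a five-membered aromatic ring with 5 heavy atoms and no hydrogen-bond donor, leaves, and 2-hydroxy-3-methoxyphenyl, a six-membered aromatic ring of carbon only with 9 heavy atoms and 1 hydrogen-bond donor, enters, yet with isobutyl on the core the two compounds cannot be told apart in this read-out. Nothing measured here explains why these two groups read alike.

The compounds shown leave open whether 2-hydroxy-3-methoxyphenyl would read the same with phenoxy in place of isobutyl, as in compound 3, which carries furan-2-yl. They also leave open how quite different groups at this place would read, such as a carboxylic acid on the ring, a saturated cyclohexyl ring or a piperidine.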